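Ethoxy in place of ethyl on a carbonyl carbon

The compounds below may be only part of what the source reports. "The series", "measured", "known", "first", "only" and "open" are said of these compounds alone.

Measured in a physicochemical assay for solubility, read by HPLC, in phosphate buffer, measured as kinetic solubility, at pH 7.4; a higher number here means a more soluble compound, a lower number a less soluble compound:
Compound 1 `CCC(=O)c1ccn(-c2ccc(S(N)(=O)=O)cc2)c1C`: 100000 nM
Compound 2 `CCC(=O)c1cc(-c2cccc(Cl)c2)n(-c2ccc(S(N)(=O)=O)cc2)c1C`: 12600 nM

Compound 2, at 12600 nM, holds the lower of the two numbers in this assay. The next compound, compound 3 `CCOC(=O)c1cc(-c2cccc(Cl)c2)n(-c2ccc(S(N)(=O)=O)cc2)c1C`, differs from it in one place: ethoxy in place of ethyl on a carbonyl carbon. In words, this is ethoxy in place of ethyl on a carbonyl carbon.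

Among the measured compounds shown here, only one measured step is available. It is the modest 7.9-fold lower number from compound 1 to compound 2 (0.90 log units; beyond the scatter), which came with 3-chlorophenyl in place of hydrogen on an aromatic carbon. That change was made on an aromatic carbon and the present one is on a carbonyl carbon, so this step gives no direct measure of what to expect here. For the measured compounds named here, no measured pair carries the present change, and the data offer no size for it. No step beyond the scatter is therefore expected in this assay, and any direction is uncertain. The expected change is a 1.3-fold lower number from compound 2 to compound 3 (0.10 log units; within the scatter). Compound 3 is estimated at 10000 nM, with an expected range from 3500 nM to 28000 nM.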

Compound 3, solubility: 9200 nM
Compound 3: middle estimate off by 1.1-fold (0.04 log units), on the high side; low and high end bracket the measured number.
By their numbers in this assay, from the lowest: compounds 3 and 2 (each within the scatter of the next); then compound 1.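

In this assay, ethoxy in place of ethyl on a carbonyl carbon gives a 1.4-fold lower number from compound 2 to compound 3 (0.14 log units; within the scatter) and so compounds 2 and 3 cannot be told apart in this read-out. Among the compounds shown here, this is the first reading at this position, as the one earlier step concerned an aromatic carbon and lay beyond the scatter, while the change from propanoyl to ethoxycarbonyl, which brings in one more oxygen and one hydrogen-bond acceptor, leaves the number within it. Nothing available explains this result.

On these data alone, the step was read only with the 3-chlorophenyl group in place, so it remains open whether the same exchange would also stay within the scatter on the core of compound 1, which lacks that group. As far as these compounds go, it also remains open whether other groups on this carbonyl carbon, such as an amine forming an amide, a free carboxylic acid or a longer chain in place of ethoxy, would move the number beyond the scatter in either direction.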